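Adding a Chloro Group to the Core of Compound 2

The source may report more compounds than this note shows. Statements on the series, on what has been measured and on what is new or still open speak of the compounds shown alone.

Compound 1, `Cc1nc2ccccc2nc1Oc1ccc(C(=O)N[C@@H](C)C(=O)O)cc1`, gives 28100 nM in a functional assay on K562 cells (Homo sapiens) for antiproliferative activity, read by MTT assay, with a stated time of 48 h; on this read-out higher numbers stand for weaker inhibition and lower numbers for stronger inhibition.
Compound 2, `Cc1nc2ccccc2nc1Oc1ccc(C(=O)N[C@@H](CC(C)C)C(=O)O)cc1`, gives 19500 nM in this assay.
Compound 3, `Cc1nc2cc(Cl)ccc2nc1Oc1ccc(C(=O)N[C@@H](C)C(=O)O)cc1`, gives 20900 nM in this assay.

These three compounds share a core in which a fused two-ring system is linked through an oxygen to a benzene ring bearing an amide, and the amide carries an amino acid. All three were measured in this assay, and all three numbers are high, meaning weak inhibition of cell growth.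

Compound 2 differs from compound 1 in one place: isopropyl in place of hydrogen on a saturated chain carbon, two bonds along the chain from an amide-type nitrogen and a carbonyl carbon. The step is a 1.4-fold lower number from compound 1 to compound 2 (0.16 log units; within the scatter), so the two values cannot be told apart. Compound 3 differs from compound 1 by chloro in place of hydrogen on an aromatic carbon, and that step is a 1.3-fold lower number from compound 1 to compound 3 (0.13 log units; within the scatter), again too small to count as a real change.

Compound 4, `Cc1nc2ccc(Cl)cc2nc1Oc1ccc(C(=O)N[C@@H](CC(C)C)C(=O)O)cc1`, has not yet been measured. It differs from compound 2 by chloro in place of hydrogen on an aromatic carbon, the same change that was made from compound 1 to compound 3, at the same place on the core. Compound 2 and compound 4 thus stand to each other as compound 1 and compound 3 do. Because the earlier step was a 1.3-fold lower number from compound 1 to compound 3 (0.13 log units; within the scatter), the step from compound 2 to compound 4 is expected to be of similar size, about a 1.3-fold lower number from compound 2 to compound 4 (0.11 log units; within the scatter). On this basis compound 4 is estimated at 15000 nM in this assay, with a likely range from 7000 nM to 35000 nM. The true test of compound 4 is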

Compound 4, half-maximal inhibitory concentration: 14500 nM
Beside the measured number, compound 4's estimate is 1.0-fold (0.01 log units) above it; low and high end bracket the measured number.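

Carried onto the core of compound 2, chloro in place of hydrogen on an aromatic carbon gives a 1.3-fold lower number from compound 2 to compound 4 (0.13 log units; within the scatter) in this assay. Set beside the earlier step, the same change gives matching results on the two cores, which differ in the chain on the amino acid: the same change on two cores in this assay, a 1.3-fold lower number (0.13 log units; within the scatter) from compound 1 to compound 3 and a 1.3-fold lower number (0.13 log units; within the scatter) from compound 2 to compound 4, 1.0-fold (0.00 log units) apart, within the scatter of two such steps. Among these compounds, this shows only that the change leaves the number within the scatter on both cores; it does not show that chloro strengthens inhibition on either core, and two pairs of compounds are too few to make a rule for the whole series.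

All four numbers remain high, and chloro is the only group shown in place of that aromatic hydrogen, so it stays open whether a different group on the core, such as methoxy or an amine, would move the number beyond the scatter. Also open, from the compounds shown here alone, is whether a longer chain on the amino acid, or an ester in place of the carboxylic acid, would do so, and whether chloro would still give a step of this size on such compounds.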